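From 4-chlorophenyl to 2-bromophenyl on a sulfonamide nitrogen

The source may report more compounds than this note shows. Statements on the series, on what has been measured and on what is new or still open speak of the compounds shown alone.

Three related sulfonamides share one core and have been measured in a functional assay on MCF7 cells (Homo sapiens) for antiproliferative activity, read by MTT assay, with a stated time of 72 h; on this read-out higher numbers stand for weaker inhibition and lower numbers for stronger inhibition. There, compound 1 `CN(c1ccc(Cl)cc1)S(=O)(=O)C1CC2OC1C(c1ccc(NC(=O)CCCCCCC(=O)O)cc1)=C2c1ccc(O)cc1` gives 13700 nM, compound 2 `CCN(c1ccccc1Cl)S(=O)(=O)C1CC2OC1C(c1ccc(NC(=O)CCCCCCC(=O)O)cc1)=C2c1ccc(O)cc1` gives 33300 nM, and compound 3 `CCN(c1ccc(Cl)cc1)S(=O)(=O)C1CC2OC1C(c1ccc(NC(=O)CCCCCCC(=O)O)cc1)=C2c1ccc(O)cc1` gives 22100 nM. Compound 3 holds the middle place among these numbers, yet its gaps to the other two, a 1.5-fold lower number from compound 2 to compound 3 (0.18 log units; within the scatter) and a 1.6-fold higher number from compound 1 to compound 3 (0.21 log units; within the scatter), both lie within the scatter.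

The next compound is compound 4 `CCN(c1ccccc1Br)S(=O)(=O)C1CC2OC1C(c1ccc(NC(=O)CCCCCCC(=O)O)cc1)=C2c1ccc(O)cc1`, which has 2-bromophenyl in place of 4-chlorophenyl on a sulfonamide nitrogen. Two measured steps offer guidance. The closest is the exchange of 2-chlorophenyl for 4-chlorophenyl, seen above as the step to compound 3, and it was small. For the measured compounds named here, the other is a 2.4-fold higher number from compound 1 to compound 2 (0.39 log units; beyond the scatter), the only step here beyond the scatter, and it is modest. It replaces (4-chlorophenyl)(methyl)amino with (2-chlorophenyl)(ethyl)amino. Going by the values given here, no measured compound carries 2-bromophenyl, so the data say nothing directly about that group.

A small move towards a higher number is therefore expected, with nothing beyond the scatter. The estimated change is a 1.4-fold higher number from compound 3 to compound 4 (0.13 log units; within the scatter). In this assay the estimate for compound 4 is 30000 nM, with an expected range from 15000 nM to 60000 nM.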

Compound 4, half-maximal inhibitory concentration: > 100000 nM
Compound 4 gave a limit, no number; the forecaster's own chance of this, stated with the estimate: 10%; at least 3.3-fold (0.52 log units) between middle value and limit.
By their numbers in this assay, from the lowest: compounds 1, 3 and 2 (each within the scatter of the next, the first and the last beyond it). At a limit, above all of these: compound 4.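

Compound 4 gives a limit in this assay, not a number: the limit of > 100000 nM in this assay, at which 1 of the 4 values shown sits.

The clearest comparison is with compound 2, where only the halogen on the same aromatic carbon changes, and it gives an at least 3.0-fold higher number from compound 2 to compound 4 (0.47 log units; beyond the scatter), while the exchange of 2-chlorophenyl for 4-chlorophenyl stayed small, with a 1.5-fold lower number from compound 2 to compound 3 (0.18 log units; within the scatter). So the earlier compounds suggested that this aryl group on the sulfonamide nitrogen could vary with little consequence, and compound 4 shows that the choice of halogen can matter far more than the earlier steps implied, as the other two steps also show, with an at least 4.5-fold higher number from compound 3 to compound 4 (0.65 log units; beyond the scatter) and an at least 7.2-fold higher number from compound 1 to compound 4 (0.86 log units; beyond the scatter).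

As far as these compounds go, all three steps rest on a limit, so they give only a lower bound on the change, and the true size remains unknown. From the compounds shown here alone, it also remains open whether the loss belongs to bromo at this one place or to bromo on the ring in general: 4-bromophenyl would address that, and 2-fluorophenyl or plain phenyl on the same nitrogen would show how the series behaves with a different halogen or with none.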